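The compounds below may be only part of what the source reports. "The series", "measured", "known", "first", "only" and "open" are said of these compounds alone.

Working notes on the series. For the measured compounds named here, in a functional assay on KB cells (Homo sapiens) for antiproliferative activity, read by sulforhodamine B assay, with a stated time of 3 days (on this read-out lower numbers stand for an effect already at smaller amounts and higher numbers for an effect only at larger amounts of compound), two compounds have numbers so far: compound 1 `CCC1=C(O)c2c(oc(-c3ccc(O)cc3)cc2=O)C(CC)(CC)C1=O` gives 20.6 uM and compound 2 `CCC1=C(O)c2c(oc(-c3ccc(C)c(C)c3)cc2=O)C(CC)(CC)C1=O` gives 35.5 uM on this read-out. Those two values lie within the scatter of each other, so compound 2 cannot be told apart from compound 1 on the numbers available. Compound 3 `CCC1=C(O)c2c(oc(-c3cc(C)c(C)cc3C)cc2=O)C(CC)(CC)C1=O` is not yet measured. Relative to compound 2 it carries methyl in place of hydrogen on an aromatic carbon so that 3,4-dimethylphenyl becomes 2,4,5-trimethylphenyl. Going by the values given here, the one measured step that bears on this is a 1.7-fold higher number from compound 1 to compound 2 (0.24 log units; within the scatter) at the same phenyl substituent, and it stays within the scatter. Among the compounds with values here, that step does not test a methyl group ortho to a large group, so the data hold no direct precedent for this change. On these data alone, no step beyond the scatter is therefore expected, and the direction stays open. The step expected is a 1.2-fold lower number from compound 2 to compound 3 (0.07 log units; within the scatter) in this assay on present evidence. Estimated for compound 3 is 30 uM within an expected range of 12 uM to 70 uM on the same read-out.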

Compound 3, concentration for half-maximal effect: 8.2 uM
Compound 3: middle estimate off by 3.7-fold (0.56 log units), on the high side; measured number below the stated range.
By their numbers in this assay, from the lowest: compound 3; then compounds 1 and 2 (each within the scatter of the next).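

In this assay, for the compounds shown here, adding a methyl group ortho to a large group on the six-membered aromatic ring gives a 4.3-fold lower number from compound 2 to compound 3 (0.64 log units; beyond the scatter), a step beyond the scatter, whereas the only earlier step at this substituent, a 1.7-fold higher number from compound 1 to compound 2 (0.24 log units; within the scatter), stayed within it. The phenyl substituent can therefore move this read-out, and 2,4,5-trimethylphenyl also separates from 4-hydroxyphenyl, with a 2.5-fold lower number from compound 1 to compound 3 (0.40 log units; beyond the scatter), which leaves compound 3 with the lowest number of the three, its steps from both others being beyond the scatter. No measurement shown here bears on why this methyl group goes with a lower number, so the step stands as an observation only.

On these data alone, whether a methoxy group, a chlorine atom or an amine at the same place would give a step of like size and direction stays open, as does whether the step depends on the two methyl groups already on the ring. As far as these compounds go, all three compounds share one core, so it is also open whether the step would carry over to a different core.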